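Bromo gives way to nitro in a small series

The compounds below may be only part of what the source reports. "The series", "measured", "known", "first", "only" and "open" are said of these compounds alone.

Compound 1 `COc1ccc(COc2cc(O)c3c(=O)cc(C)oc3c2[C@H]2CCN(C)C[C@H]2O)cc1` with 35% measured
Compound 2 `Cc1cc(=O)c2c(O)cc(OCc3ccc(Br)cc3)c([C@H]3CCN(C)C[C@H]3O)c2o1` with 17% measured

In a functional assay on PC-3 cells (Homo sapiens) for inhibition, read by MTT assay, with a stated time of 48 h, tested at 10 uM (on this read-out lower numbers stand for less inhibition of growth and higher numbers for more inhibition of growth at the one concentration tested), compound 2 holds the lower of the two numbers, at 17% so far. Compound 3 `Cc1cc(=O)c2c(O)cc(OCc3ccc([N+](=O)[O-])cc3)c([C@H]3CCN(C)C[C@H]3O)c2o1` has not yet been measured. It differs from compound 2 by nitro in place of bromo on an aromatic carbon, para to a large group (nitro in place of bromo on an aromatic carbon). For the measured compounds named here, one measured step bears on this change: a number 18 percentage points lower from compound 1 to compound 2 (beyond the scatter) with bromo in place of methoxy on an aromatic carbon. That step is modest and beyond the scatter, but it involves no nitro, so it guides the size of the change more than its direction. Compound 2 sits at the low end, so a small rise is expected in this assay and it may stay within the scatter. The expected change is a number 7 percentage points higher from compound 2 to compound 3 (within the scatter) on this reasoning. Compound 3 is estimated at 24% (expected range 8% to 42%).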

Compound 3, percent growth inhibition at one concentration: 23%
Beside the measured number, compound 3's estimate is 1 percentage points above it; the range from low to high includes it.
By their numbers in this assay, from the lowest: compounds 2 and 3 (each within the scatter of the next); then compound 1.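

In this assay, the 4-bromobenzyl and 4-nitrobenzyl groups could not be told apart: nitro in place of bromo on this aromatic carbon gives a number 6 percentage points higher from compound 2 to compound 3 (within the scatter) and so adds no clear change at this position. Methoxy stays separate from nitro as it did from bromo, with a number 12 percentage points lower from compound 1 to compound 3 (beyond the scatter), so among these three groups only the methoxy of compound 1 stands apart from the other two. Nothing available explains why these groups read as they do.

On these data alone, whether an amine or a carboxylic acid on this carbon would fall with bromo and nitro or with methoxy remains open. So does whether a longer chain on the oxygen, such as ethoxy, would keep the higher reading of compound 1.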